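This account rests on a few compounds, and the source may have more. Where it says the series, first, only, none or still open, it means among the compounds named here.

In a functional assay on HCT-116 cells (Homo sapiens) for inhibition, read by MTT assay, with a stated time of 48 h (on this read-out lower numbers stand for stronger inhibition and higher numbers for weaker inhibition), three compounds sharing one core have been measured: compound 1 (`COc1cc(-c2nnc(SCc3ccccc3)n2-c2ccc(N(C)C)cc2)cc(OC)c1OC`) gives 54000 nM, compound 2 (`COc1cc(-c2nnc(SCC(=O)c3ccccc3)n2-c2ccc(N(C)C)cc2)cc(OC)c1OC`) gives 42500 nM, and compound 3 (`COc1cc(-c2nnc(SCC(=O)c3ccc4ccccc4c3)n2-c2ccc(N(C)C)cc2)cc(OC)c1OC`) gives 54500 nM. These three values lie within the scatter of one another, so compound 3 does not stand apart. Compound 4 (`CCOC(=O)CSc1nnc(-c2cc(OC)c(OC)c(OC)c2)n1-c1ccc(N(C)C)cc1`) brings one change to compound 3: ethoxy in place of naphthalen-2-yl on a carbonyl carbon. For the measured compounds named here, the steps that bear on it are a 1.3-fold higher number from compound 2 to compound 3 (0.11 log units; within the scatter), a 1.3-fold lower number from compound 1 to compound 2 (0.10 log units; within the scatter) and a 1.0-fold higher number from compound 1 to compound 3 (0.00 log units; within the scatter), all small and within the scatter. Going by the values given here, no measured compound carries ethoxy on that carbonyl carbon, so this comparison is only a loose guide. In this assay, no step beyond the scatter is expected, and the expected step is a 1.1-fold lower number from compound 3 to compound 4 (0.04 log units; within the scatter). For compound 4, the estimated value is 50000 nM, within an expected range of 25000 nM to 100000 nM.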

Compound 4, half-maximal inhibitory concentration: > 60000 nM
Compound 4: no number, only a limit; the forecaster's own chance of this, stated with the estimate: 10%; at least 1.2-fold (0.07 log units) between middle value and limit.
By their numbers in this assay, from the lowest: compounds 2, 1 and 3 (each within the scatter of the next). At a limit, above all of these: compound 4.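

In this assay, compound 4 gives a limit, not a number: the limit of > 60000 nM in this assay, at which 1 of the 4 values shown sits. Ethoxy is the first group on this carbonyl carbon without a ring, and the steps read an at least 1.1-fold higher number from compound 3 to compound 4 (0.04 log units; that floor lies within the scatter), an at least 1.4-fold higher number from compound 2 to compound 4 (0.14 log units; that floor lies within the scatter) and an at least 1.1-fold higher number from compound 1 to compound 4 (0.04 log units; that floor lies within the scatter). From the compounds shown here alone, each is only a floor, so the true size of the change remains unknown and ethoxy cannot be ranked against phenyl or naphthalen-2-yl.

Still open, going by these compounds, is how far compound 4's true value lies past its limit. Also open, on these data alone, is whether a carboxylic acid or an amide with an amine nitrogen on this carbonyl carbon would give a measurable number.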